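Compound 4: 4-methylpiperazin-1-yl in place of isopropyl

The compounds below may be only part of what the source reports. "The series", "measured", "known", "first", "only" and "open" are said of these compounds alone.

In a functional assay on MCF7 cells (Homo sapiens) for inhibition, read by MTT assay, with a stated time of 72 h (a higher number here means a weaker inhibitor, a lower number a stronger inhibitor), compound 1 `CC(C)c1ccc(NC(=O)C2CCN(C/C=C/c3ccccc3)CC2)cc1` gives 9100 nM. Compound 3 `O=C(Nc1ccc(F)c(Br)c1)C1CCN(C/C=C/c2ccccc2)CC1` gives 13500 nM, and the step of a 1.5-fold higher number from compound 1 to compound 3 (0.17 log units; within the scatter) leaves these two inseparable. Compound 2 `O=C(Nc1cccc(F)c1)C1CCN(C/C=C/c2ccccc2)CC1` gives 33000 nM, so compound 1 shares the low end of the three numbers with compound 3, while compound 2 stands apart, with the step of a 3.6-fold higher number from compound 1 to compound 2 (0.56 log units; beyond the scatter).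

Compound 4 `CN1CCN(c2ccc(NC(=O)C3CCN(C/C=C/c4ccccc4)CC3)cc2)CC1` carries one change from compound 1: 4-methylpiperazin-1-yl in place of isopropyl on an aromatic carbon. This is 4-methylpiperazin-1-yl in place of isopropyl on an aromatic carbon.

Among the compounds with values here, the only guides are the measured exchanges of the aryl group on the amide-type nitrogen. Besides the two steps above, there is the step of a 2.4-fold lower number from compound 2 to compound 3 (0.39 log units; beyond the scatter). Each of these removes or alters the aryl substitution, and none brings in a ring on the aryl group, so they offer only a rough size. Neither compound lacking the isopropyl group shows a number clearly lower than that of compound 1, and compound 2 shows the step of a 3.6-fold higher number from compound 1 to compound 2 (0.56 log units; beyond the scatter). A modest move to a higher number is therefore expected, of a size within the span of those steps.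

For compound 4 the estimated step is a 2.2-fold higher number from compound 1 to compound 4 (0.34 log units; beyond the scatter). For compound 4 the expected value is 20000 nM, with an estimated range of 7000 nM to 50000 nM.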

Compound 4, half-maximal inhibitory concentration: 44000 nM
Estimate against measurement, compound 4: 2.2-fold (0.34 log units) below; low and high end bracket the measured number.
By their numbers in this assay, from the lowest: compounds 1 and 3 (each within the scatter of the next); then compounds 2 and 4 (each within the scatter of the next).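

In this assay, the only exchange shown that leaves the rest of the aryl group untouched, 4-methylpiperazin-1-yl in place of isopropyl on an aromatic carbon para to a large group, gives a 4.8-fold higher number from compound 1 to compound 4 (0.68 log units; beyond the scatter). The earlier steps shown here altered the substitution of the aryl group as a whole and could not isolate this position; this single exchange shows that the number responds to the group held there, and that a larger entering group with a six-membered non-aromatic ring and 2 hetero atoms does not lower it from that of compound 1. No measurement here offers an explanation for this step, so it stands as an observation on one pair of compounds.

Several features enter together in this exchange, so the ring, the added size and the two ring nitrogens cannot be told apart from this pair. Cyclohexyl, morpholin-4-yl and dimethylamino at the same place would separate these features, while a methyl or a hydrogen there would show whether isopropyl itself contributes to the number of compound 1.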